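The source may report more compounds than this note shows. Statements on the series, on what has been measured and on what is new or still open speak of the compounds shown alone.

Compound 2 `C=C(Br)C(=O)Nc1ccc2c(c1)/C(=C\c1sccc1C)C(=O)N2` gives 0.9 nM in a functional assay on CCRF-CEM cells (Homo sapiens) for antiproliferative activity, read by MTT assay, with a stated time of 72 h (a higher number here means a weaker inhibitor, a lower number a stronger inhibitor), the lowest of the two numbers recorded there. Going by the values given here, its nearest neighbour is compound 1 `C=C(Br)C(=O)Nc1ccc2c(c1)/C(=C\c1cccs1)C(=O)N2`, which gives 710 nM in this assay; the single measured step is a 790-fold lower number from compound 1 to compound 2 (2.90 log units; beyond the scatter), a large one, produced by a methyl in place of hydrogen on an aromatic carbon.

Compound 3 `C=C(Br)C(=O)Nc1ccc2c(c1)/C(=C/c1sccc1C)C(=O)N2` is the next compound to be measured in this assay. It differs from compound 2 as follows: the two compounds have the same atoms and bonds and differ only in configuration as drawn: 1 of 1 stereo elements differ; a double bond is drawn E in compound 2 and Z in compound 3. Among the compounds with values here, no measured step concerns a change of configuration; the only step recorded, from compound 1 to compound 2, concerns a methyl group and so does not bear on this one. The expectation for compound 3 therefore rests only on the number for compound 2, namely 0.9 nM, with nothing in the data to say whether drawing the double bond the other way will move the number beyond the scatter or leave it where it is.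

Compound 3 is accordingly estimated at 8 nM in this assay, within a wide range of 0.8 nM to 200 nM, which corresponds to an expected step of an 8.9-fold higher number from compound 2 to compound 3 (0.95 log units; beyond the scatter).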

Compound 3, half-maximal inhibitory concentration: 0.5 nM
Beside the measured number, compound 3's estimate is 16-fold (1.20 log units) above it, outside the stated range (below it).
By their numbers in this assay, from the lowest: compounds 3 and 2 (each within the scatter of the next); then compound 1.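

In this assay, going by these compounds alone, the configuration of the double bond, the one feature not yet tested in the earlier compounds, does not separate the two methyl-bearing compounds: the measured step is a 1.8-fold lower number from compound 2 to compound 3 (0.26 log units; within the scatter). Set against a 790-fold lower number from compound 1 to compound 2 (2.90 log units; beyond the scatter), which is large and comes from a methyl in place of hydrogen on an aromatic carbon, this shows that the two single changes recorded so far do not carry the same weight, since only the methyl step lies beyond the scatter. The comparison isolates the double bond, with nothing else in the two structures to account for a step of either size: the fact that compounds 2 and 3 differ only in the configuration as drawn.

The compounds shown leave open whether the configuration is equally without consequence when the methyl is absent, as compound 1, the only compound lacking it, appears in a single drawn configuration. They also leave open what an ethyl group, a methoxy group or a chlorine in place of that methyl would give in this assay, in either configuration of the double bond.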